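Compound 3 to compound 4: one aryl group for another

This account rests on a few compounds, and the source may have more. Where it says the series, first, only, none or still open, it means among the compounds named here.

Values in a functional assay on HCT-116 cells (Homo sapiens) for antiproliferative activity, read by MTT assay; a higher number here means a weaker inhibitor, a lower number a stronger inhibitor:
- compound 1 `Cn1c(=O)c(=O)n(C2CCCC2)c2nc(N/N=C/c3ccccc3)ncc21`: > 100000 nM, a limit of the assay
- compound 2 `Cn1c(=O)c(=O)n(C2CCCC2)c2nc(N/N=C/c3ccc(S(C)(=O)=O)cc3)ncc21`: 86600 nM
- compound 3 `COc1cccc(/C=N/Nc2ncc3c(n2)n(C2CCCC2)c(=O)c(=O)n3C)c1`: 45800 nM

Among the compounds with values here, compound 3 stands level with the only other actual number in this assay: a 1.9-fold lower number from compound 2 to compound 3 (0.28 log units; within the scatter). Neither of these two compounds can be ranked over the other.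

Next in line is compound 4 `Cn1c(=O)c(=O)n(C2CCCC2)c2nc(N/N=C/c3ccc(C(F)(F)F)cc3)ncc21`, which carries 4-(trifluoromethyl)phenyl in place of 3-methoxyphenyl on a carbon with a double bond to nitrogen.

Within the data shown here, three measured steps bear on this change. Two of them add a group to the phenyl of compound 1: an at least 1.1-fold lower number from compound 1 to compound 2 (0.06 log units; that floor lies within the scatter) for methylsulfonyl, and an at least 2.1-fold lower number from compound 1 to compound 3 (0.33 log units; beyond the scatter) for methoxy. Both are only lower bounds on the size of the step because of the limit of > 100000 nM in this assay, at which 1 of the 3 values shown sits. Among the measured compounds shown here, the closest precedent is the exchange of one substituted phenyl for another, compound 2 against compound 3, and that step of a 1.9-fold lower number from compound 2 to compound 3 (0.28 log units; within the scatter) stayed within the scatter.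

On that basis, no step beyond the scatter is expected in this assay, with a slight lean towards a higher number. The estimated step is a 1.2-fold higher number from compound 3 to compound 4 (0.08 log units; within the scatter). For compound 4 the expected value is 55000 nM, with an estimated range of 25000 nM to 100000 nM. A limit instead of a number remains possible for compound 4.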

Compound 4, half-maximal inhibitory concentration: 29000 nM
For compound 4 the middle estimate is 1.9-fold (0.28 log units) above the measured one, and the stated range covers the measured number.
By their numbers in this assay, from the lowest: compounds 4, 3 and 2 (each within the scatter of the next, the first and the last beyond it). At a limit, above all of these: compound 1.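

In this assay, the exchange of aryl groups on the carbon with a double bond to nitrogen reads as a 1.6-fold lower number from compound 3 to compound 4 (0.20 log units; within the scatter), so 3-methoxyphenyl and 4-(trifluoromethyl)phenyl cannot be ranked at this position. Within the data shown here, the new information comes from the comparison of trifluoromethyl with methylsulfonyl on the aromatic carbon, which reads as a 3.0-fold lower number from compound 2 to compound 4 (0.48 log units; beyond the scatter); this is the first step between two actual numbers to pass the scatter, and it shows that the choice of group on the phenyl can shift the number in this assay, though only modestly. The comparison with the unsubstituted phenyl reads as an at least 3.4-fold lower number from compound 1 to compound 4 (0.53 log units; beyond the scatter), and it gives a floor rather than a size because of a value that is not a number: the limit of > 100000 nM in this assay, at which 1 of the 4 values shown sits.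

The compounds shown leave open how an amine or a carboxylic acid on the phenyl would read in this assay. They also leave open whether a longer chain in place of cyclopentyl on the shared core would change the picture, since that group is the same throughout.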